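Selenocyanate carbamates: para substituent on the phenyl ester

The source may report more compounds than this note shows. Statements on the series, on what has been measured and on what is new or still open speak of the compounds shown alone.

Measured so far in a functional assay on PC-3 cells (Homo sapiens) for cytotoxicity, read by MTT assay, with a stated time of 72 h; on this read-out lower numbers stand for stronger inhibition of growth and higher numbers for weaker inhibition of growth:
compound 1 `COc1ccc(OC(=O)Nc2ccc([Se]C#N)cc2)cc1` gives 44600 nM
compound 2 `N#C[Se]c1ccc(NC(=O)Oc2ccc(F)cc2)cc1` gives 40400 nM
compound 3 `Cc1ccc(OC(=O)Nc2ccc([Se]C#N)cc2)cc1` gives 32300 nM

Compound 3 holds the lowest of the three numbers, yet the gaps are small: a 1.3-fold lower number from compound 2 to compound 3 (0.10 log units; within the scatter) and a 1.4-fold lower number from compound 1 to compound 3 (0.14 log units; within the scatter) both sit within the scatter, so no order among the three is established. Compound 4 `N#C[Se]c1ccc(NC(=O)Oc2ccc(Cl)cc2)cc1` carries the change (chloro in place of methyl on an aromatic carbon). Within the data shown here, the steps that bear on it are the swaps of the same ring position already seen: a 1.1-fold lower number from compound 1 to compound 2 (0.04 log units; within the scatter), a 1.4-fold lower number from compound 1 to compound 3 (0.14 log units; within the scatter) and a 1.3-fold lower number from compound 2 to compound 3 (0.10 log units; within the scatter), none beyond the scatter. A halogen in place of methyl is therefore expected to move this assay little, with the step of a 1.1-fold higher number from compound 3 to compound 4 (0.03 log units; within the scatter) judged as none beyond the scatter. Compound 4 is estimated at 35000 nM, in the range 17000 nM to 70000 nM.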

Compound 4, concentration for total growth inhibition: 18700 nM
Beside the measured number, compound 4's estimate is 1.9-fold (0.27 log units) above it; measured number inside the range.
By their numbers in this assay, from the lowest: compounds 4, 3, 2 and 1 (each within the scatter of the next, the first and the last beyond it).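

In this assay chloro at this position gives the first gaps beyond the scatter in the series: a 2.2-fold lower number from compound 2 to compound 4 (0.33 log units; beyond the scatter) and a 2.4-fold lower number from compound 1 to compound 4 (0.38 log units; beyond the scatter) are both modest and a 1.7-fold lower number from compound 3 to compound 4 (0.24 log units; within the scatter) stays within the scatter. The position is therefore not wholly flat, though chloro cannot be separated from methyl here. Nothing available explains the difference between these groups.

Still open, going by these compounds, is whether bromo, trifluoromethyl or an amine at this position would widen these gaps. Also open, on these data alone, is whether a change elsewhere on the shared core would move the number further.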